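A few compounds are considered here, and "the series" means these few. Any claim that something is new, unique, unknown or untested is made for them only; others in the source may bear on it.

Two compounds have been measured in a functional assay on SK-MEL-5 cells (Homo sapiens) for inhibition, read by sulforhodamine B assay, with a stated time of 48 h; a lower number here means a stronger inhibitor of growth, a higher number a weaker inhibitor of growth:

Compound 1 `O=C(Nc1cccc(-n2cc(-c3ccncc3)c(-c3ccc(Cl)c(O)c3)n2)c1)Nc1cccc(C(F)(F)F)c1` gives 1300 nM in this assay.
Compound 2 `COc1cc(-c2nn(-c3cccc(NC(=O)Nc4cc(C(F)(F)F)cc(C(F)(F)F)c4)c3)cc2-c2ccncc2)ccc1Cl` gives 694 nM in this assay.

Of these two numbers, compound 1 holds the higher one, but the number for compound 2 sits within the usual scatter of such measurements, so the two cannot be told apart on what is in hand. Compound 3 `O=C(Nc1cccc(-n2cc(-c3ccncc3)c(-c3ccc(Cl)c(O)c3)n2)c1)Nc1ccc(Cl)c(Cl)c1` has not yet been measured. It differs from compound 1 in one place: 3,4-dichlorophenyl in place of 3-(trifluoromethyl)phenyl on an amide-type nitrogen. Within the data shown here, no pair of measured compounds differs only at this position, so there is no measured step to lean on, and nothing here says how the two groups compare.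

With that in mind, the expectation for compound 3 is a small step, a 1.3-fold lower number from compound 1 to compound 3 (0.11 log units; within the scatter), which would not reach beyond the scatter in either direction. Among the measured compounds shown here, compound 3 is therefore expected to give about 1000 nM in this assay, with a range from 300 nM to 3500 nM allowing for the uncertainty that remains when no comparable step has been measured.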

Compound 3, concentration for 50% growth inhibition: 570 nM
Compound 3: middle estimate off by 1.8-fold (0.24 log units), on the high side; the measured number falls inside the stated range.
By their numbers in this assay, from the lowest: compounds 3, 2 and 1 (each within the scatter of the next, the first and the last beyond it).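

In this assay, among these compounds, putting 3,4-dichlorophenyl in place of 3-(trifluoromethyl)phenyl on the amide-type nitrogen gives a 2.3-fold lower number from compound 1 to compound 3 (0.36 log units; beyond the scatter), the first measured step at this position. The position therefore responds to the group it carries, though only modestly, since this step lies only just beyond the usual scatter. Neither group carries a hydrogen-bond donor, a hydrogen-bond acceptor or a net charge, and growth inhibition is kept with either one, but nothing measured here says why the number moves.

The compounds shown leave open whether both chlorines are needed, which a phenyl ring carrying a single chlorine or a plain phenyl ring would help to settle. They also leave open how far this position tolerates a different kind of group, such as an amine, a carboxylic acid or a longer alkyl chain in place of the substituted phenyl ring, since both groups compared here are halogen-bearing phenyl rings.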